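The source may hold more compounds than are shown below. What is called first, only, known or untested is meant among the compounds shown, and "the series" means these compounds.

Compounds measured so far:
- compound 1, `O[C@@H](c1ccccc1)[C@H]1CO[C@H](c2ccccc2)[C@@H](C/C=C/c2cccc(F)c2)C1`: 9170 nM
- compound 2, `COc1ccc(/C=C/C[C@H]2C[C@@H]([C@@H](O)c3ccc(OC)c(OC)c3)CO[C@@H]2c2ccc(OC)c(OC)c2)cc1OC`: 34700 nM

For the measured compounds named here, in a functional assay on HL-60 cells (Homo sapiens) for cytotoxicity, read by WST assay, with a stated time of 48 h (a lower number here means a stronger inhibitor, a higher number a weaker inhibitor), compound 1 gives 9170 nM, the lower of the two numbers known here. Compound 2 gives 34700 nM, a higher number that lies beyond the usual scatter; the two structures differ in several places at once, so nothing more is drawn from this pair.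

Compound 3, `Oc1ccccc1/C=C/C[C@H]1C[C@@H]([C@@H](O)c2ccccc2)CO[C@@H]1c1ccccc1`, has not yet been tested in this assay. It differs from compound 1 in one place: 2-hydroxyphenyl in place of 3-fluorophenyl on a double-bonded chain carbon bound to a double-bonded chain carbon. Going by the values given here, the shared core is untouched, and only one ring group is exchanged for another.

Among the compounds with values here, no measured pair shows what such an exchange does, so the expected step is small. The expectation from compound 1 to compound 3 is a 1.1-fold higher number from compound 1 to compound 3 (0.04 log units; within the scatter), a change of about the size of repeat measurements, in no firm direction. For compound 3 the expected value is therefore 10000 nM, with a range from 4000 nM to 30000 nM.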

Compound 3, half-maximal inhibitory concentration: 10800 nM
Beside the measured number, compound 3's estimate is 1.1-fold (0.03 log units) below it, and the stated range covers the measured number.
By their numbers in this assay, from the lowest: compounds 1 and 3 (each within the scatter of the next); then compound 2.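

In this assay, putting 2-hydroxyphenyl in place of 3-fluorophenyl on a double-bonded chain carbon bound to a double-bonded chain carbon leaves the number unchanged within the scatter (a 1.2-fold higher number from compound 1 to compound 3 (0.07 log units; within the scatter)). For the compounds shown here, this is the first reading at this position, and it shows that the exchange of fluorine for a ring hydroxyl, which brings in a hydrogen-bond donor and a hydrogen-bond acceptor, does not shift the reading here. Nothing available accounts for this result.

The two group names differ both in the atom on the ring and in the number that gives its place, so this single step cannot separate those two changes. Going by these compounds, whether an amine, a carboxylic acid or a longer chain in this place would move the number stays open.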